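A few compounds are considered here, and "the series" means these few. Any claim that something is new, unique, unknown or untested is made for them only; others in the source may bear on it.

Compounds measured:
- compound 1, `O=C(/C=C/C=C/c1ccccc1)c1cc(Cl)ccc1O`: 54.8 nM
- compound 2, `O=C(/C=C(O)/C=C/c1ccccc1)c1ccccc1O`: 1160 nM
- compound 3, `O=C(/C=C/C=C/c1ccc([N+](=O)[O-])cc1)c1ccccc1O`: 160 nM

The three measured compounds were tested in an in vitro assay on cells for inhibition of Amine oxidase [flavin-containing] B (Homo sapiens), read by Amplex Red, with a stated time of 15 min; on this read-out lower numbers stand for stronger inhibition and higher numbers for weaker inhibition. Among them compound 2 gives the highest of the three numbers. Compound 3, its nearest neighbour on this scale, sits beyond the usual scatter with a lower number, and compound 1, the furthest, sits still lower, also well beyond the scatter. Among the measured compounds shown here, no pair among the measured compounds differs in a single place, so no measured step can be read directly from these data.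

Compound 4, `Cc1ccc(/C=C/C(O)=C/C(=O)c2ccccc2O)cc1`, is the unmeasured compound of interest. It is reached from compound 2 by one change, (methyl in place of hydrogen on an aromatic carbon), the new group standing para to a large group on the six-membered aromatic ring of carbon only. Nothing measured here shows what this particular change does on this core. Given that compound 2 gives 1160 nM in this assay, and that the change adds only a single carbon, the step from compound 2 to compound 4 is expected to be small, a 1.3-fold lower number from compound 2 to compound 4 (0.11 log units; within the scatter), likely within the scatter or a slight move toward a lower number. Compound 4 is therefore estimated at 900 nM, with a range from 300 nM to 3000 nM.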

Compound 4, half-maximal inhibitory concentration: 3770 nM
For compound 4 the middle estimate is 4.2-fold (0.62 log units) below the measured one; measured number above the stated range.
By their numbers in this assay, from the lowest: compound 1; then compound 3; then compound 2; then compound 4.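

In this assay, among the compounds shown here, this is the first direct reading of a single change on the shared core: methyl in place of hydrogen on an aromatic carbon, para to a large group, gives a 3.3-fold higher number from compound 2 to compound 4 (0.51 log units; beyond the scatter), a modest move toward weaker inhibition. The earlier compounds shown here offered no pair differing in one place, so they could not show that this position responds at all; here, the addition of one carbon is enough to move the number beyond the usual scatter, and phenyl to 4-methylphenyl is not a neutral exchange on this core. Nothing measured in the material shown accounts for the move.

It remains open whether the weakening belongs to methyl alone or would also appear with another group at this place, such as a fluorine, a chlorine, a methoxy group or an amine, none of which stands among the compounds shown. For the compounds shown here, compound 3 carries a nitro group on that ring but differs from compound 2 in more than one place, so no step between them, or any other step involving that group, can be read.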